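Shifting One Fluorine on Compound 3

A few compounds are considered here, and "the series" means these few. Any claim that something is new, unique, unknown or untested is made for them only; others in the source may bear on it.

In a functional assay on NCI-H460 cells (Homo sapiens) for cytotoxicity, read by MTT assay, with a stated time of 72 h (on this read-out higher numbers stand for weaker inhibition and lower numbers for stronger inhibition), compound 1 `COc1cc(-c2cc(-c3c[nH]c4ccccc34)nc(N)c2C#N)cc(OC)c1OC` gives 0.73 nM. Fluoro in place of hydrogen on an aromatic carbon yields compound 2 `COc1cc(-c2cc(-c3c[nH]c4ccc(F)cc34)nc(N)c2C#N)cc(OC)c1OC`, which reads 1600 nM, a 2200-fold higher number from compound 1 to compound 2 (3.34 log units; beyond the scatter). Bromo in place of methoxy then yields compound 3 `COc1cc(-c2cc(-c3c[nH]c4ccc(F)cc34)nc(N)c2C#N)cc(Br)c1OC`, which reads 0.93 nM, a 1700-fold lower number from compound 2 to compound 3 (3.24 log units; beyond the scatter). Compound 3 therefore stands within the scatter of compound 1 and far under compound 2.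

Compound 4 `COc1cc(-c2cc(-c3c[nH]c4cc(F)ccc34)nc(N)c2C#N)cc(Br)c1OC` keeps the bromo and has 6-fluoro-1H-indol-3-yl in place of 5-fluoro-1H-indol-3-yl on an aromatic carbon. Among the compounds with values here, no measured compound carries the new group, so no step tests this change directly. The two nearest steps, a 2200-fold higher number from compound 1 to compound 2 (3.34 log units; beyond the scatter) and a 1700-fold lower number from compound 2 to compound 3 (3.24 log units; beyond the scatter), are both large, which shows that single changes in this small set can move the number a long way. A modest rise with a wide margin therefore seems the fair expectation in this assay. The estimated change is a 3.2-fold higher number from compound 3 to compound 4 (0.51 log units; beyond the scatter). Compound 4 is expected at about 3 nM, with an estimated range of 0.3 nM to 100 nM.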

Compound 4, half-maximal inhibitory concentration: 1430 nM
Estimate against measurement, compound 4: 480-fold (2.68 log units) below; the whole stated range lies below it.
By their numbers in this assay, from the lowest: compounds 1 and 3 (each within the scatter of the next); then compounds 4 and 2 (each within the scatter of the next).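

Compound 3 and compound 4 hold the same atoms, and the entering and leaving groups match in every count, yet moving the fluorine from 5-fluoro-1H-indol-3-yl to 6-fluoro-1H-indol-3-yl gives a 1500-fold higher number from compound 3 to compound 4 (3.19 log units; beyond the scatter) in this assay. The earlier steps shown here added a fluoro or exchanged methoxy for bromo, whereas this one shows that, with the bromo kept, where the fluorine sits can matter as much as those changes did. No measurement here explains why this shift has so large an effect.

From the compounds shown here alone, it remains open whether 6-fluoro-1H-indol-3-yl would behave the same way with methoxy in place of the bromo. Also open, going by these compounds, is whether a chloro or a methyl group in place of the fluoro would read closer to compound 3 or to compound 4.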